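Turning the Benzamido Group Around

This account rests on a few compounds, and the source may have more. Where it says the series, first, only, none or still open, it means among the compounds named here.

Compound 1 `COc1cc(C(=O)N2CO[C@](CCN3CCC(NC(=O)c4ccccc4)CC3)(c3ccc(Cl)c(Cl)c3)C2)cc(OC)c1OC`: 89%
Compound 2 `COc1cc(C(=O)N2CO[C@](CCN3CCN(c4ncccn4)CC3)(c3ccc(Cl)c(Cl)c3)C2)cc(OC)c1OC`: 100%

In an assay on isolated protein for inhibition of Substance-P receptor (Cavia porcellus), tested at 1 ug/mL (on this read-out higher numbers stand for more inhibition at the one concentration tested (going by the name of the read-out) and lower numbers for less inhibition), compound 1 gives 89%, the lower of the two numbers; compound 2 gives 100%, which lies above it by more than the usual scatter. Compound 3 `COc1cc(C(=O)N2CO[C@](CCN3CCC(C(=O)Nc4ccccc4)CC3)(c3ccc(Cl)c(Cl)c3)C2)cc(OC)c1OC` differs from compound 1 by phenylcarbamoyl in place of benzamido on a saturated ring carbon. Among the compounds with values here, no measured pair shows the effect of such a change in this assay, so the step can only be guessed; with the same atoms joined differently, a small downward shift, not beyond the scatter, is expected. Compound 3 is expected to give about 84%, in the range 62% to 97%. The estimated step of a number 5 percentage points lower from compound 1 to compound 3 (within the scatter) is small.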

Compound 3, a percentage reported as inhibition, at one concentration (the size of the read-out at that concentration, not a potency): 44%
The estimate for compound 3 lay 40 percentage points above the measured number; measured number outside the range, below it.
By their numbers in this assay, from the lowest: compound 3; then compound 1; then compound 2.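

Joining the same atoms differently on this saturated ring carbon is no neutral swap: in this assay the change lowers inhibition by a large step, a number 45 percentage points lower from compound 1 to compound 3 (beyond the scatter), well beyond the scatter. Within the data shown here, at this position, then, the direction of the amide link matters, and not only which atoms are present; the earlier compounds held no pair that could show this. Nothing available explains the drop. On these data alone, it remains open whether an amine or a carboxylic acid on this ring carbon would hold the inhibition of compound 1, or whether a longer chain to the phenyl ring would restore it in compound 3.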